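Sulfonyl in Place of Methyl on a Ring Nitrogen

The source may report more compounds than this note shows. Statements on the series, on what has been measured and on what is new or still open speak of the compounds shown alone.

For the measured compounds named here, compound 2 `CN1CCN(C(=O)Cn2c(=O)c3c(ncn3C)n(C)c2=O)CC1` is one of two compounds measured so far. In a functional assay on MGC-803 cells (Homo sapiens) for inhibition, read by MTT assay, with a stated time of 48 h, tested at 20 uM (on this read-out lower numbers stand for less inhibition and higher numbers for more inhibition at the one concentration tested (going by the name of the read-out)), compound 2 gives 8.6%, and compound 1 `Cn1cnc2c1c(=O)n(CC(=O)OC(C)(C)C)c(=O)n2C` gives 17.2%. The step between them, a number 8.6 percentage points lower from compound 1 to compound 2 (within the scatter), lies within the scatter, so neither compound can be called weaker or stronger than the other. Going by the values given here, that step, in which 4-methylpiperazin-1-yl replaced tert-butoxy on a carbonyl carbon, is the only measured comparison available.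

Compound 3 `Cc1ccc(S(=O)(=O)N2CCN(C(=O)Cn3c(=O)c4c(ncn4C)n(C)c3=O)CC2)cc1` differs from compound 2 in one place: (4-methylphenyl)sulfonyl in place of methyl on an amine nitrogen in a ring. Among the compounds with values here, no measured step touches this ring nitrogen; the single known step concerns the group on the carbonyl carbon and was itself within the scatter. The data thus give no ground for a shift in either direction, and a step no larger than the scatter is expected for a number 1.4 percentage points higher from compound 2 to compound 3 (within the scatter). Compound 3 is accordingly estimated to give 10% in this assay, with a range from 0% to 28%.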

Compound 3, a percentage reported as inhibition, at one concentration (the size of the read-out at that concentration, not a potency): 20.1%
The estimate for compound 3 lay 10.1 percentage points below the measured number, within the range that was stated.
By their numbers in this assay, from the lowest: compounds 2, 1 and 3 (each within the scatter of the next, the first and the last beyond it).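

In this assay, the amine nitrogen in a ring proves to be a place where a change of group registers: putting (4-methylphenyl)sulfonyl in place of methyl gives a number 11.5 percentage points higher from compound 2 to compound 3 (beyond the scatter). For the compounds shown here, this is the first step to pass beyond the scatter, and it is modest, whereas the change on the carbonyl carbon, a number 8.6 percentage points lower from compound 1 to compound 2 (within the scatter), did not pass it. The step also shows that this nitrogen can carry a group with a six-membered aromatic ring and a sulfonyl without the number falling, though nothing available explains the rise.

The sulfonyl and the aromatic ring entered together, so the compounds shown do not tell which part goes with the step, and it remains open whether methanesulfonyl, benzoyl or benzyl on the same nitrogen would give a similar number. Also open, from the compounds shown here alone, is whether a chloro or methoxy group in place of the methyl on the aromatic ring would move the number further, and whether the step would hold at other concentrations.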